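The source may hold more compounds than are shown below. What is called first, only, known or untested is meant among the compounds shown, and "the series" means these compounds.

The measured compounds:

Compound 1 `c1ccc(-c2cnccn2)c(OCC2=NCCN2)c1`: in a functional assay for activation of Alpha-1D adrenergic receptor (Homo sapiens), read by calcium flux (on this read-out higher numbers stand for an effect only at larger amounts of compound and lower numbers for an effect already at smaller amounts), compound 1 gives < 100000 nM, which is a limit of the assay and not a number.

Compound 2 `c1c[nH]c(-c2ccccc2OCC2=NCCN2)c1`: in this assay compound 2 gives 6.31 nM.

Compound 3 `c1ccc(-c2ccns2)c(OCC2=NCCN2)c1`: in this assay compound 3 gives 25.1 nM.

Of the two numbers shown, compound 3 carries the higher one; the step of a 4.0-fold higher number from compound 2 to compound 3 (0.60 log units; beyond the scatter) is modest but beyond the scatter. The steps a step that the limit leaves unreadable from compound 1 to compound 2 and a step that the limit leaves unreadable from compound 1 to compound 3 cannot be sized because of the limit of < 100000 nM in this assay, at which 1 of the 3 values shown sits. Compound 4 `Cc1ccoc1-c1ccccc1OCC1=NCCN1` is not yet measured. It differs from compound 3 in one place: 3-methylfuran-2-yl in place of 1,2-thiazol-5-yl on an aromatic carbon. Among the measured compounds shown here, the one readable step that bears on this change, a 4.0-fold higher number from compound 2 to compound 3 (0.60 log units; beyond the scatter), shows that exchanging one five-membered aromatic ring for another here moves the number modestly. A five-membered ring with a single hetero atom, as in compound 2 with 6.31 nM, gave a lower number than compound 3. A modest drop in this assay is therefore expected, a 2.1-fold lower number from compound 3 to compound 4 (0.32 log units; beyond the scatter). Compound 4 is estimated at 12 nM, between 3 nM and 50 nM.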

Compound 4, half-maximal effective concentration: < 100000 nM
Compound 4 ended at the assay's limit (the forecaster's own chance of this, stated with the estimate: 5%); the middle value does not contradict the limit.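

No new step can be read for compound 4 against compound 1, compound 2 or compound 3, because its result is a limit and not a number: the limit of < 100000 nM in this assay, at which 2 of the 4 values shown sit. The compounds shown leave open whether the methyl group or the furan ring of 3-methylfuran-2-yl accounts for the result of compound 4 in this assay.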